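A Methoxy Step Repeated on a Rearranged Core

The compounds below may be only part of what the source reports. "The series", "measured", "known", "first", "only" and "open" are said of these compounds alone.

Compound 1 `c1cc(OCc2ccc(-c3nn[nH]n3)cc2)cc(OCc2ccc3ccccc3n2)c1` is the starting point. In a functional assay (lung) for inhibition, with Cavia porcellus as the target (a higher number here means a weaker inhibitor, a lower number a stronger inhibitor), compound 1 gives 12 nM. Compound 2 `COc1cc(-c2nn[nH]n2)ccc1COc1cccc(OCc2ccc3ccccc3n2)c1` differs from compound 1 by one change, (methoxy in place of hydrogen on an aromatic carbon). That change made a 1.3-fold lower number from compound 1 to compound 2 (0.12 log units; within the scatter), and in this assay compound 2 gives 9 nM. Compound 3 `c1cc(COc2ccc(-c3nn[nH]n3)cc2)cc(OCc2ccc3ccccc3n2)c1` has the same atoms as compound 1 joined differently; the difference between the two cores is not broken down here. In this assay compound 3 gives 14 nM, close to the values of compound 1 and compound 2. Compound 4 `COc1cc(-c2nn[nH]n2)ccc1OCc1cccc(OCc2ccc3ccccc3n2)c1` is not yet measured and carries the same change on the core of compound 3, (methoxy in place of hydrogen on an aromatic carbon). Because a 1.3-fold lower number from compound 1 to compound 2 (0.12 log units; within the scatter) stayed within the scatter, a step of similar size, a 1.3-fold lower number from compound 3 to compound 4 (0.10 log units; within the scatter), is expected. Compound 4 is estimated at 11 nM in this assay, with a likely range from 5 nM to 25 nM.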

Compound 4, half-maximal inhibitory concentration: 36 nM
Compound 4: middle estimate off by 3.3-fold (0.51 log units), on the low side; measured number above the stated range.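

On the rearranged core, methoxy in place of hydrogen on an aromatic carbon gave a 2.6-fold higher number from compound 3 to compound 4 (0.41 log units; beyond the scatter) in this assay. The same change therefore did not behave as a fixed step across these two cores: the same change on two cores in this assay, a 1.3-fold lower number (0.12 log units; within the scatter) from compound 1 to compound 2 and a 2.6-fold higher number (0.41 log units; beyond the scatter) from compound 3 to compound 4, 3.4-fold (0.54 log units) apart, beyond the scatter of two such steps. Among the compounds shown here, this is only one pair of steps, so it shows that the outcome of this change can depend on the core, but it does not show why, and it gives no rule for other cores or other groups.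

The compounds shown leave open whether this weaker result is specific to methoxy or would also appear with a hydroxyl, a fluorine or an ethoxy in the same place. Also open, going by these compounds, is how methoxy would behave elsewhere on the same six-membered aromatic ring.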